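The source may report more compounds than this note shows. Statements on the series, on what has been measured and on what is new or still open speak of the compounds shown alone.

Compound 1 `O=C(NCCCCc1ccccc1)n1c(=O)oc2ccccc21` gives 64 nM in an assay on HEK293 cells for inhibition of acid ceramidase (Homo sapiens), with a stated time of 10 min; on this read-out higher numbers stand for weaker inhibition and lower numbers for stronger inhibition.
Compound 2 `O=C(NCCCCc1ccccc1)n1c(=O)oc2cc(Cl)c(Cl)cc21` gives 18 nM in this assay.
Compound 3 `O=C(NCCCCc1ccccc1)n1c(=O)oc2ccc(F)cc21` gives 12 nM in this assay.

Compound 3 has the lowest number of the three, though its gap to compound 2 lies within the scatter; only compound 1 is clearly higher. Compound 4 `O=C(NCCCCc1ccccc1)n1c(=O)oc2ccc(Cl)cc21` differs from compound 3 by chloro in place of fluoro on an aromatic carbon. For the measured compounds named here, no measured pair shows exactly this exchange. Going by the values given here, the one related step is a 5.3-fold lower number from compound 1 to compound 3 (0.73 log units; beyond the scatter), where fluoro in place of hydrogen lowered the number, and compound 2, which carries chloro rather than fluoro, gives a number close to that of compound 3. A swap of one halogen for another is therefore expected to move the number little, if at all, beyond the scatter. For compound 4 the estimate is 12 nM, within 5 nM to 30 nM, which is expected to be no change at the digits printed from compound 3 to compound 4 (within the scatter).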

Compound 4, half-maximal inhibitory concentration: 15 nM
Compound 4: middle estimate off by 1.3-fold (0.10 log units), on the low side; the measured number falls inside the stated range.
By their numbers in this assay, from the lowest: compounds 3, 4 and 2 (each within the scatter of the next); then compound 1.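

Chloro in place of fluoro gives a 1.3-fold higher number from compound 3 to compound 4 (0.10 log units; within the scatter) in this assay, so at this aromatic carbon the two halogens cannot be told apart. Chloro in place of hydrogen gives a 4.3-fold lower number from compound 1 to compound 4 (0.63 log units; beyond the scatter), so a single chloro here, like fluoro, goes with a lower number than hydrogen, while hydrogen in place of one chloro gives a 1.2-fold lower number from compound 2 to compound 4 (0.08 log units; within the scatter). Nothing available explains why the two halogens match here.

From the compounds shown here alone, whether methoxy, an amine or a carboxylic acid on this carbon would keep the number this low remains open.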